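A few compounds are considered here, and "the series" means these few. Any claim that something is new, unique, unknown or untested is made for them only; others in the source may bear on it.

Compound 1 `NC(=O)c1c(NC(=O)Nc2ccc(Cl)cc2)sc2c1CCN(C1CCOCC1)C2`: 2830 nM
Compound 2 `CC(C)(C)OC(=O)CCN1CCc2c(sc(NC(=O)Nc3ccc(Cl)cc3)c2C(N)=O)C1`: 1100 nM
Compound 3 `CC(C)(C)OC(=O)CN1CCc2c(sc(NC(=O)Nc3ccc(Cl)cc3)c2C(N)=O)C1`: not yet measured

For the measured compounds named here, in a functional assay (strain AB) with Danio rerio as the target, read by microscopy, with a stated time of 1 h (a lower number here means that less compound is needed, a higher number that more compound is needed for the effect), compound 2 has the lower of the two numbers so far, at 1100 nM. Compound 1 stands higher, at 2830 nM.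

The next change keeps the ester and shortens the chain on the amine nitrogen in a ring, from 2-(tert-butoxycarbonyl)ethyl to (tert-butoxycarbonyl)methyl: tert-butoxycarbonyl in place of (tert-butoxycarbonyl)methyl on a saturated chain carbon bound to an amine nitrogen in a ring.

Going by the values given here, only one measured step bears on this change: a 2.6-fold lower number from compound 1 to compound 2 (0.41 log units; beyond the scatter). That modest step swapped oxan-4-yl for 2-(tert-butoxycarbonyl)ethyl at the same nitrogen, so it is indirect evidence. Among the compounds with values here, it involved a much larger replacement than the present one, and no measured pair isolates chain length. A smaller step is therefore expected in this assay, with at most a slight rise and probably nothing beyond the scatter, though the direction is uncertain.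

The expected step is a 1.2-fold higher number from compound 2 to compound 3 (0.07 log units; within the scatter). For compound 3 the estimated value is 1300 nM, with an expected range of 500 nM to 3500 nM.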

Compound 3, half-maximal effective concentration: > 25000 nM
Compound 3: a limit, no number; the forecaster's own chance of this, stated with the estimate: 3%; middle value at least 19-fold (1.28 log units) from the limit.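

Compound 3 gives no number in this assay, only a limit: the limit of > 25000 nM in this assay, at which 1 of the 3 values shown sits.

The earlier compounds shown here showed only a swap of one whole group for another at the amine nitrogen in a ring, a 2.6-fold lower number from compound 1 to compound 2 (0.41 log units; beyond the scatter), and said nothing about chain length. With the tert-butoxycarbonyl ester kept, going from 2-(tert-butoxycarbonyl)ethyl to (tert-butoxycarbonyl)methyl gives an at least 22-fold higher number from compound 2 to compound 3 (1.35 log units; beyond the scatter), so the length of the chain at this nitrogen, on its own, carries a large part of the read-out, and a small edit here is not a neutral one. The (tert-butoxycarbonyl)methyl group also stands behind oxan-4-yl, an at least 8.8-fold higher number from compound 1 to compound 3 (0.94 log units; beyond the scatter), so among the three groups shown the ester does not help at this nitrogen unless the longer chain carries it.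

Still open, on these data alone, is whether a longer chain, such as 3-(tert-butoxycarbonyl)propyl, would lower the number further or whether the 2-(tert-butoxycarbonyl)ethyl length is already the best of the series. Also open, as far as these compounds go, is whether the ester matters at all, which a carboxylic acid or a primary amide on the same chain, or a plain ethyl or propyl group, would test.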